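Ring-Nitrogen Substituent Swap and Rat Microsomal Stability

The source may hold more compounds than are shown below. What is called first, only, known or untested is meant among the compounds shown, and "the series" means these compounds.

Compound 1 `[O-][S+](CCNC1CCN(Cc2ccc(F)cc2)CC1)C(c1ccc(F)cc1)c1ccc(F)cc1` and compound 2 `[O-][S+](CCNC1CCN(CC(O)Cc2ccccc2)CC1)C(c1ccc(F)cc1)c1ccc(F)cc1` share one core and differ only in the group on the amine nitrogen in the ring. In an ADME assay on microsomes from liver (Rattus norvegicus) for metabolic stability, read by LC-MS, using NADPH, tested at 10 uM (a lower number here means that less of the compound is left, a higher number that more of the compound is left), compound 1 gives 100%, and compound 2 gives 100%. The move from compound 1 to compound 2 was no change at the digits printed from compound 1 to compound 2 (within the scatter), so compound 2 stands level with compound 1 at the digits shown, both at the top of the scale. Compound 3 `O=C(c1ccc(F)cc1)N1CCC(NCC[S+]([O-])C(c2ccc(F)cc2)c2ccc(F)cc2)CC1` carries (4-fluorophenyl)carbonyl in place of 2-hydroxy-3-phenylpropyl on an amine nitrogen in a ring. Among the compounds with values here, the only measured step at this position, the one from compound 1 to compound 2, left the read-out unmoved within the scatter, though it swapped a group on a saturated chain carbon rather than bringing in a carbonyl, so it is not the same kind of change. Both measured values sit at full remaining. From there no rise is possible. Compound 3 is therefore expected to show a step of a number 10 percentage points lower from compound 2 to compound 3 (within the scatter) in this assay. The estimated value for compound 3 is 90%, with a range from 65% to 100%.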

Compound 3, percent of the compound remaining: 100%
The estimate for compound 3 lay 10 percentage points below the measured number, within the range that was stated.
By their numbers in this assay, from the lowest: compounds 1, 2 and 3 (each within the scatter of the next).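

Putting a carbonyl directly on the amine nitrogen in a ring, which neither earlier compound has, gave no change at the digits printed from compound 2 to compound 3 (within the scatter) in this assay when (4-fluorophenyl)carbonyl replaced 2-hydroxy-3-phenylpropyl. The replacement of 4-fluorobenzyl by the same group gave no change at the digits printed from compound 1 to compound 3 (within the scatter) as well, so three different groups at this position now share one reading at the top of the scale, and the change from an amine nitrogen bearing a saturated chain carbon to one bearing a carbonyl leaves no mark on this read-out. Nothing given here bears on why the reading stays the same.

With all three readings at the top of the scale, any difference among these groups that lies beyond its reach stays hidden. From the compounds shown here alone, it remains open whether a carboxylic acid or a longer chain on the same nitrogen would bring the reading down.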